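This account rests on a few compounds, and the source may have more. Where it says the series, first, only, none or still open, it means among the compounds named here.

Working notes on the series.

Compound 1 `O=CN1N=C(c2ccc(Cl)cc2)CC1c1cn(-c2ccccc2)nc1-c1ccc(Cl)c(Cl)c1` is the reference point. In a functional assay on the whole organism (strain Wistar) for inhibition, with Rattus norvegicus as the target, read by paw edema, with stated times of 30 min and 60 min, at a dose of 50 mg/kg by the oral route (on this read-out lower numbers stand for less inhibition and higher numbers for more inhibition at the one dose given (going by the name of the read-out)), compound 1 gives 51.1%. Compound 2 `Clc1ccc(C2=NN(c3ccccc3)C(c3cn(-c4ccccc4)nc3-c3ccc(Cl)c(Cl)c3)C2)cc1` differs from compound 1 by one change, (phenyl in place of formyl on an amine nitrogen in a ring), and in this assay compound 2 gives 53.4%; the step is a number 2.3 percentage points higher from compound 1 to compound 2 (within the scatter). Compound 3 `Cc1ccc(C2=NN(C=O)C(c3cn(-c4ccccc4)nc3-c3ccc(Cl)c(Cl)c3)C2)cc1` differs from compound 1 by methyl in place of chloro on an aromatic carbon, which is also the only counted difference between the core of compound 1 and the core of compound 3. In this assay compound 3 gives 53.4%, a step of a number 2.3 percentage points higher from compound 1 to compound 3 (within the scatter). Compound 2 and compound 3 are level at the digits recorded, and all three numbers sit within the usual scatter of one another, so no ordering among them is claimed.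

Compound 4 `Cc1ccc(C2=NN(c3ccccc3)C(c3cn(-c4ccccc4)nc3-c3ccc(Cl)c(Cl)c3)C2)cc1` has not yet been measured. It stands to compound 3 as compound 2 stands to compound 1: phenyl in place of formyl on an amine nitrogen in a ring. The surroundings are not word for word the same: in the first pair the ring atom two ring bonds away bears a 4-chlorophenyl group, in the second a 4-methylphenyl group, so this is the same kind of change rather than the same change. Going by the values given here, the one earlier instance of it, compound 1 to compound 2, moved the read-out only within the scatter.

On that basis the step from compound 3 to compound 4 in this assay is expected to be a number 2.1 percentage points higher from compound 3 to compound 4 (within the scatter), resting on a number 2.3 percentage points higher from compound 1 to compound 2 (within the scatter), with the caveat that a single prior instance is a thin footing. Compound 4 is therefore estimated at 55.5%, between 47% and 64%.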

Compound 4, a percentage reported as inhibition, in the whole organism at one dose (the size of the read-out at that dose, not a potency): 58.8%
Beside the measured number, compound 4's estimate is 3.3 percentage points below it, within the range that was stated.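

In this assay, phenyl in place of formyl on an amine nitrogen in a ring gives a number 5.4 percentage points higher from compound 3 to compound 4 (within the scatter), and this does not differ from the earlier instance of the change: the same change on two cores in this assay, a number 2.3 percentage points higher (within the scatter) from compound 1 to compound 2 and a number 5.4 percentage points higher (within the scatter) from compound 3 to compound 4, 3.1 percentage points apart, within the scatter of two such steps Methyl in place of chloro on an aromatic carbon gives a number 5.4 percentage points higher from compound 2 to compound 4 (within the scatter), and this also does not differ from its earlier instance: the same change on two cores in this assay, a number 2.3 percentage points higher (within the scatter) from compound 1 to compound 3 and a number 5.4 percentage points higher (within the scatter) from compound 2 to compound 4, 3.1 percentage points apart, within the scatter of two such steps Each change therefore carries between the two cores shown without a difference that stands clear of the scatter, but each step also lies within the scatter, so neither change is shown to have an effect of its own, and two instances per change make no general rule for the series.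

The compounds shown leave open what an acetyl group or a benzyl group would give on the same amine nitrogen, and what a methoxy group or a carboxylic acid would give on the aromatic carbon that carries chloro or methyl. With a single oral dose and only the inhibition read-out at hand, potency across doses also remains open, as does any separation among these four compounds.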